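A few compounds are considered here, and "the series" means these few. Any claim that something is new, unique, unknown or untested is made for them only; others in the source may bear on it.

Series notes, cytotoxicity.

Compound 1 `COc1ccc(C(/C=C/c2ccc(Cl)cc2)=N/O)cc1` is the reference; in an ADME assay on cells (Mus musculus, strain Balb/c) for cytotoxicity, read by MTT assay, with a stated time of 48 h (on this read-out lower numbers stand for higher toxicity in this test and higher numbers for lower toxicity in this test), compound 1 gives 291000 nM. Compound 2 `COc1ccc(C(/C=C/c2ccc(Cl)cc2Cl)=N/O)cc1` differs from compound 1 by chloro in place of hydrogen on an aromatic carbon and in this assay compound 2 gives 25000 nM, a step of a 12-fold lower number from compound 1 to compound 2 (1.07 log units; beyond the scatter). Compound 3 `Cc1ccc(C(/C=C/c2ccc(Cl)cc2)=N/O)cc1` differs from compound 1 in its core by methyl in place of methoxy on an aromatic carbon and in this assay compound 3 gives 21300 nM, a step of a 14-fold lower number from compound 1 to compound 3 (1.14 log units; beyond the scatter). The values of compound 2 and compound 3 lie within the scatter of each other.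

Compound 4 `Cc1ccc(C(/C=C/c2ccc(Cl)c(Cl)c2)=N/O)cc1` is not yet measured. It differs from compound 3 by chloro in place of hydrogen on an aromatic carbon. This is the same kind of change as that from compound 1 to compound 2, not the same: in compound 2 the chloro enters ortho to a large group and meta to a chloro group, in compound 4 ortho to a chloro group and meta to a large group.

A step toward a lower number is expected from compound 3 to compound 4, about a 3.6-fold lower number from compound 3 to compound 4 (0.55 log units; beyond the scatter), smaller than a 12-fold lower number from compound 1 to compound 2 (1.07 log units; beyond the scatter). Among the compounds with values here, the surroundings of the entering chloro are not the same in the two cases, and no measured pair shows how much that matters. In this assay compound 4 is estimated at 6000 nM, with a range of 1500 nM to 25000 nM.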

Compound 4, half-maximal cytotoxic concentration: 14700 nM
The estimate for compound 4 lay 2.5-fold (0.39 log units) below the measured number; the measured number falls inside the stated range.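

Chloro in place of hydrogen on an aromatic carbon does not carry over at one size between the two cores in this assay: the same change on two cores in this assay, a 12-fold lower number (1.07 log units; beyond the scatter) from compound 1 to compound 2 and a 1.4-fold lower number (0.16 log units; within the scatter) from compound 3 to compound 4, 8.0-fold (0.90 log units) apart, beyond the scatter of two such steps

On the core of compound 3 the change gives a 1.4-fold lower number from compound 3 to compound 4 (0.16 log units; within the scatter) and so stays within the scatter, which means the large step on the core of compound 1 cannot be assumed for this change across the series. Within the data shown here, this does not show whether the gap goes with the core or with the place of the chloro, as the two pairs differ in both and each core offers only one such pair.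

Open, from the compounds shown here alone, is what the chloro would do on the core of compound 1 at the place it takes in compound 4, and on the core of compound 3 at the place it takes in compound 2. The compounds shown also leave open how fluoro, a nitrile or an amine would read at that aromatic carbon.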